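The source may report more compounds than this note shows. Statements on the series, on what has been measured and on what is new or still open speak of the compounds shown alone.

In a functional assay on PC-3 cells (Homo sapiens) for inhibition, read by sulforhodamine B assay, with a stated time of 48 h (on this read-out lower numbers stand for stronger inhibition of growth and higher numbers for weaker inhibition of growth), compound 1 (`COc1ccc(/C=C/C2(C)C=CC(=O)O2)cc1OC`) gives 176000 nM, compound 2 (`COc1cc(OC)c(OC)cc1/C=C/C1(C)C=CC(=O)O1`) gives 184000 nM and compound 3 (`COc1cc(/C=C/C2(C)C=CC(=O)O2)cc(OC)c1OC`) gives 131000 nM. Compound 1 therefore stands within the scatter of both other compounds. Compound 4 (`COc1cccc(/C=C/C2(C)C=CC(=O)O2)c1`) differs from compound 1 by hydrogen in place of methoxy on an aromatic carbon. Among the compounds with values here, two measured steps bear on this change, both methoxy in place of hydrogen on an aromatic carbon: a 1.0-fold higher number from compound 1 to compound 2 (0.02 log units; within the scatter) and a 1.3-fold lower number from compound 1 to compound 3 (0.13 log units; within the scatter). Neither is the exact reverse of the change in compound 4, but with both steps this small, no step beyond the scatter is expected in this assay. The expected step is a 1.0-fold lower number from compound 1 to compound 4 (0.02 log units; within the scatter). The estimated value for compound 4 is 170000 nM, with an expected range from 95000 nM to 300000 nM.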

Compound 4, concentration for total growth inhibition: 31600 nM
Estimate against measurement, compound 4: 5.4-fold (0.73 log units) above, outside the stated range (below it).
By their numbers in this assay, from the lowest: compound 4; then compounds 3, 1 and 2 (each within the scatter of the next).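

Removing this methoxy does what adding a methoxy to compound 1 did not: it gives a 5.6-fold lower number from compound 1 to compound 4 (0.75 log units; beyond the scatter). The methoxy on this carbon, para to a group of 9 heavy atoms, therefore matters to growth inhibition, even though the added methoxy groups of compounds 2 and 3 left the number within the scatter. Nothing measured here gives a reason for this step.

The compounds shown leave open whether only hydrogen on this carbon gives the lower number, or whether a fluorine, a hydroxyl or an amine would do the same. They also leave open what replacing the remaining methoxy group with hydrogen would do.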